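Hydroxamate aryl exchange on the shared core: working notes

The compounds below may be only part of what the source reports. "The series", "measured", "known", "first", "only" and "open" are said of these compounds alone.

Measured so far in an assay on isolated protein for inhibition of protein deacetylase HDAC6 (Homo sapiens), read by fluorescence, with a stated time of 30 min; on this read-out higher numbers stand for weaker inhibition and lower numbers for stronger inhibition:
compound 1 `COc1cc2c(NCC3CCN(Cc4ccc(C(=O)NO)cc4)CC3)cc(-c3ccc(C)o3)nc2cc1OCCCN1CCCC1` — 53 nM
compound 2 `COc1cc2nc(-c3ccc(C)o3)cc(NCC3CCN(Cc4ccc(C(=O)NO)cc4)CC3)c2cc1OC` — 84 nM

Among the measured compounds shown here, compound 2 stands at one end of the two numbers obtained in this assay, with compound 1 as its only neighbour; the single step between them, a 1.6-fold higher number from compound 1 to compound 2 (0.20 log units; within the scatter), is within the scatter, so the two compounds are read as equivalent on this read-out.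

The next compound, compound 3 `COc1cc2nc(-c3ccc(C)o3)cc(NCC3CCN(Cc4ccc(C(=O)NO)s4)CC3)c2cc1OC`, has not yet been measured in this assay. It differs from compound 2 in one place: 5-(hydroxycarbamoyl)thiophen-2-yl in place of 4-(hydroxycarbamoyl)phenyl on a saturated chain carbon bound to an amine nitrogen in a ring. For the measured compounds named here, no measured step touches the hydroxamate-bearing aryl group; the one step available concerns a distant substituent on the shared core and was itself within the scatter. There is therefore no basis in the present numbers for expecting a step beyond the scatter in either direction, and the starting point for compound 3 is the number of compound 2.

The step from compound 2 to compound 3 is estimated as a 1.2-fold higher number from compound 2 to compound 3 (0.08 log units; within the scatter). Compound 3 is accordingly expected at 100 nM, with a range from 35 nM to 300 nM, the width of the range reflecting the absence of any precedent for this change in the series.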

Compound 3, half-maximal inhibitory concentration: 66 nM
The estimate for compound 3 lay 1.5-fold (0.18 log units) above the measured number, and the stated range covers the measured number.
By their numbers in this assay, from the lowest: compounds 1, 3 and 2 (each within the scatter of the next).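

In this assay, among the compounds shown here, the first measured change at the hydroxamate-bearing aryl group, 5-(hydroxycarbamoyl)thiophen-2-yl in place of 4-(hydroxycarbamoyl)phenyl on a saturated chain carbon bound to an amine nitrogen in a ring, gives a 1.3-fold lower number from compound 2 to compound 3 (0.10 log units; within the scatter), so the two compounds are read as equivalent on this read-out. The earlier step concerned only a distant substituent on the shared core; this one shows that, with the core of compound 2, one five-membered aromatic ring with 1 hetero atom can stand in for one six-membered aromatic ring of carbon only without a step beyond the scatter. No supporting measurement is available to account for this result.

Open, from the compounds shown here alone, is whether this equivalence carries over to other rings bearing the hydroxamic acid, such as a furan or a pyridine, or to a longer chain between the ring and the hydroxamic acid. Also open, going by these compounds, is whether the thiophene exchange gives the same reading on the core of compound 1, which carries the 2-(pyrrolidin-1-yl)ethyl group, and whether a carboxylic acid could take the place of the hydroxamic acid.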